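The source may hold more compounds than are shown below. What is called first, only, known or untested is meant among the compounds shown, and "the series" means these compounds.

Compound 1 `COc1cc(CC(O)c2ccc(-c3ccc(C=O)cc3)cc2)c([N+](=O)[O-])cc1OC`: in an ADME assay on HeLa Rh cells (Homo sapiens) for cytotoxicity, read by microscopy (a higher number here means that more compound is tolerated, a lower number that less compound is tolerated), compound 1 reaches only a limit of the assay, > 245000 nM.
Compound 2 `COc1cc(CC(O)c2ccc(-c3ccc(C)cc3)cc2)c([N+](=O)[O-])cc1OC`: compound 2 gives 4700 nM.
Compound 3 `COc1cc(CC(O)c2ccc(-c3ccccc3F)cc2)c([N+](=O)[O-])cc1OC`: compound 3 gives 5000 nM.

Compound 2 has the lowest of the two numbers, and compound 3 sits within the scatter of it: a 1.1-fold higher number from compound 2 to compound 3 (0.03 log units; within the scatter). Compound 4 `COc1cc(CC(O)c2ccc(-c3cccs3)cc2)c([N+](=O)[O-])cc1OC` has not yet been measured; it differs from compound 2 in one place: thiophen-2-yl in place of 4-methylphenyl on an aromatic carbon. For the measured compounds named here, of the measured steps, the only one that exchanges the whole ring at this position, a 1.1-fold higher number from compound 2 to compound 3 (0.03 log units; within the scatter), left the number where it was, while an at least 52-fold lower number from compound 1 to compound 2 (1.71 log units; beyond the scatter) and an at least 49-fold lower number from compound 1 to compound 3 (1.69 log units; beyond the scatter) both start from the limit of > 245000 nM in this assay, at which 1 of the 3 values shown sits, and say nothing about which ring stands there. A step within the scatter is therefore expected, a 1.1-fold higher number from compound 2 to compound 4 (0.03 log units; within the scatter). Compound 4 is estimated at 5000 nM, between 2000 nM and 12000 nM.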

Compound 4, half-maximal cytotoxic concentration: 11000 nM
Compound 4: the middle estimate sits 2.2-fold (0.34 log units) below what was measured; measured number inside the range.
By their numbers in this assay, from the lowest: compounds 2 and 3 (each within the scatter of the next); then compound 4. At a limit, above all of these: compound 1.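

Replacing the six-membered ring with thiophen-2-yl at this position moves the number beyond the scatter, towards more compound tolerated: a 2.3-fold higher number from compound 2 to compound 4 (0.37 log units; beyond the scatter), and a 2.2-fold higher number from compound 3 to compound 4 (0.34 log units; beyond the scatter). The exchange of one ring for another here is therefore not always silent, although both of these steps are modest. The remaining step, an at least 22-fold lower number from compound 1 to compound 4 (1.34 log units; beyond the scatter), starts from a limit of the assay and gives only a minimum size.

Whether the sulfur atom or the smaller ring accounts for the shift stays open. So does how a furan-2-yl ring, a pyridine ring or a carboxylic acid at this position would behave in this assay.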